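Amide series: spirocyclic diamine replacing 3-aminopyrrolidine

The source may report more compounds than this note shows. Statements on the series, on what has been measured and on what is new or still open speak of the compounds shown alone.

Of the compounds shown here, two have numbers so far. Compound 1 `CN(C)c1ccc2cc(NC(=O)CCc3ccc(C(F)(F)F)cc3)ccc2n1` gives 13 nM in an assay on isolated protein for displacement of a labelled ligand from melanin-concentrating hormone receptor 1 (Homo sapiens); on this read-out lower numbers stand for stronger inhibition and higher numbers for weaker inhibition. Compound 2 `NC1CCN(c2ccc3cc(NC(=O)CCc4ccc(C(F)(F)F)cc4)ccc3n2)C1` gives 12 nM in this assay. For the measured compounds named here, the single step between them, a 1.1-fold lower number from compound 1 to compound 2 (0.03 log units; within the scatter), shows that exchanging the dimethylamino for the 3-aminopyrrolidin-1-yl on an aromatic carbon left the read-out essentially unchanged. Compound 2 therefore holds the lower of the two numbers, but the gap to compound 1 is within the scatter, so no order between them can be claimed.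

Compound 3 `O=C(CCc1ccc(C(F)(F)F)cc1)Nc1ccc2nc(N3CCC4(CCNC4)C3)ccc2c1` differs from compound 2 in one place: a group of 9 heavy atoms (7 carbon, 2 nitrogen; 2 five-membered non-aromatic rings with 1 hetero atom each) in place of a group of 6 heavy atoms (4 carbon, 2 nitrogen; one five-membered non-aromatic ring with 1 hetero atom), on an aromatic carbon. The group that enters keeps one hydrogen-bond donor and two hydrogen-bond acceptors, as the group that leaves did, and adds a second five-membered non-aromatic ring. Going by the values given here, the only measured step that bears on this position, a 1.1-fold lower number from compound 1 to compound 2 (0.03 log units; within the scatter), was within the scatter, so the expectation for this assay is a step of a 1.3-fold higher number from compound 2 to compound 3 (0.10 log units; within the scatter), no larger than the scatter and without a clear direction. Compound 3 is expected to give about 15 nM, with a range from 5 nM to 45 nM.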

Compound 3, half-maximal inhibitory concentration: 0.5 nM
For compound 3 the middle estimate is 30-fold (1.48 log units) above the measured one; the whole stated range lies above it.
By their numbers in this assay, from the lowest: compound 3; then compounds 2 and 1 (each within the scatter of the next).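

In this assay this position, which had seemed indifferent when 3-aminopyrrolidin-1-yl took the place of dimethylamino, proves able to carry a large change: the spirocyclic diamine gives a 24-fold lower number from compound 2 to compound 3 (1.38 log units; beyond the scatter) and also gives a 26-fold lower number from compound 1 to compound 3 (1.41 log units; beyond the scatter) when set against the ringless dimethylamino group. The group that enters and the group that leaves have the same counts of hydrogen-bond donors and acceptors, so those counts do not separate compound 2 from compound 3; what differs is the second five-membered non-aromatic ring and the larger number of heavy atoms. No measurement at hand bears on the origin of this step.

Still open, going by these compounds, is whether the step belongs to this one spirocyclic diamine or extends to related groups, such as piperazine or a spirocycle with a piperidine ring in place of one of the five-membered rings. Also open, on these data alone, is whether the free ring amine is needed, which a methyl or acetyl group on that nitrogen would test.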